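From Methyl to Acetamido in an Antiproliferative Series

The source may report more compounds than this note shows. Statements on the series, on what has been measured and on what is new or still open speak of the compounds shown alone.

In a functional assay on MCF7 cells (Homo sapiens) for antiproliferative activity, read by MTT assay, with a stated time of 48 h (on this read-out lower numbers stand for stronger inhibition and higher numbers for weaker inhibition), compound 1 (`COc1ccc(-c2c(Nc3ccc(F)cc3)c3ccc(OC)cc3oc2=O)cc1`) gives > 100000 nM, which is a limit of the assay and not a number. Compound 2 (`CCOc1ccc(Nc2c(-c3ccc(OC)cc3)c(=O)oc3cc(OC)ccc23)cc1`) gives 24300 nM, and compound 3 (`COc1ccc(-c2c(Nc3ccc(C)cc3)c3ccc(OC)cc3oc2=O)cc1`) gives 66900 nM, the higher of these two numbers. Compound 4 (`COc1ccc(-c2c(Nc3ccc(NC(C)=O)cc3)c3ccc(OC)cc3oc2=O)cc1`) carries acetamido in place of methyl on an aromatic carbon. Three measured steps change this same place: an at least 4.1-fold lower number from compound 1 to compound 2 (0.61 log units; beyond the scatter), an at least 1.4-fold lower number from compound 1 to compound 3 (0.17 log units; that floor lies within the scatter) and a 2.8-fold higher number from compound 2 to compound 3 (0.44 log units; beyond the scatter). Going by these compounds, only ethoxy gives a clear gain over methyl, and acetamido is untested, so the guide is weak. A modest drop is expected, a 2.2-fold lower number from compound 3 to compound 4 (0.35 log units; beyond the scatter). For compound 4 the estimated value is 30000 nM, with an expected range of 9000 nM to 90000 nM.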

Compound 4, half-maximal inhibitory concentration: 85800 nM
Beside the measured number, compound 4's estimate is 2.9-fold (0.46 log units) below it; measured number inside the range.
By their numbers in this assay, from the lowest: compound 2; then compounds 3 and 4 (each within the scatter of the next). At a limit, above all of these: compound 1.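

With acetamido in place of methyl, which brings a hydrogen-bond donor and acceptor, the step stays within the scatter: a 1.3-fold higher number from compound 3 to compound 4 (0.11 log units; within the scatter). Acetamido does not match ethoxy, however: a 3.5-fold higher number from compound 2 to compound 4 (0.55 log units; beyond the scatter). Compound 1 stands at a limit of the assay and not at a number, and its step to compound 4 is only a floor: an at least 1.1-fold lower number from compound 1 to compound 4 (0.06 log units; that floor lies within the scatter). The limit is this: the limit of > 100000 nM in this assay, at which 1 of the 4 values shown sits.

Still open, going by these compounds, is whether ethoxy's advantage extends to other groups at this place. A longer propoxy chain, a smaller methoxy or a free amine could each compare differently with ethoxy.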